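Replacing the sulfonamide arm of the shared core

This account rests on a few compounds, and the source may have more. Where it says the series, first, only, none or still open, it means among the compounds named here.

Measured compounds:
compound 1 `Cc1ccc(-c2c(C)cccc2C(=O)Nc2ccc3c(c2)CC(NS(=O)(=O)c2ccccc2)C3)cc1` with 93 nM
compound 2 `Cc1cccc(C(=O)Nc2ccc3c(c2)CC(NS(=O)(=O)c2ccccc2)C3)c1-c1ccc(C#N)cc1` with 120 nM
compound 3 `Cc1cccc(C(=O)Nc2ccc3c(c2)CC(NS(=O)(=O)c2ccccc2)C3)c1-c1ccc(Cl)cc1` with 100 nM

In an assay on isolated protein for inhibition of microsomal triglyceride transfer protein large subunit (Homo sapiens) (a higher number here means a weaker inhibitor, a lower number a stronger inhibitor), compound 3 sits second highest of the three numbers, but its neighbours lie close: the step of a 1.1-fold higher number from compound 1 to compound 3 (0.03 log units; within the scatter) and the step of a 1.2-fold lower number from compound 2 to compound 3 (0.08 log units; within the scatter) are both within the scatter, so the three compounds cannot be set apart from one another on these numbers. All three measured steps, including a 1.3-fold higher number from compound 1 to compound 2 (0.11 log units; within the scatter), concern only the substituent on the pendant aromatic ring and say nothing about the sulfonamide arm.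

Compound 4 `Cc1cccc(C(=O)Nc2ccc3c(c2)CC(CNS(C)(=O)=O)C3)c1-c1ccc(Cl)cc1` changes exactly that arm: (methanesulfonamido)methyl in place of (phenylsulfonyl)amino on a saturated ring carbon. Within the data shown here, no measured step bears on this part of the structure, so the account can only set a wide range. Because compound 3 gives 100 nM in this assay, and the change removes an aromatic ring while keeping one donor and two acceptors, a weaker result for compound 4 is expected, with a step of a 3.0-fold higher number from compound 3 to compound 4 (0.48 log units; beyond the scatter) in this assay. The expected value for compound 4 is 300 nM, with a range from 70 nM to 1500 nM.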

Compound 4, half-maximal inhibitory concentration: 500 nM
For compound 4 the middle estimate is 1.7-fold (0.22 log units) below the measured one, within the range that was stated.
By their numbers in this assay, from the lowest: compounds 1, 3 and 2 (each within the scatter of the next); then compound 4.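

Unlike the three earlier steps, which stayed within the scatter and touched only the pendant aromatic ring, this change to the sulfonamide arm moves the number in this assay beyond the scatter, with a 5.0-fold higher number from compound 3 to compound 4 (0.70 log units; beyond the scatter). The saturated ring carbon is thus a place where the substituent matters: the compound is a weaker inhibitor with (methanesulfonamido)methyl, which has no ring, than with (phenylsulfonyl)amino, although the hydrogen-bond donor and acceptor counts are the same. No measurement shown here accounts for this step. The swap removes the phenyl ring and also adds a methylene link, so the compounds shown do not separate these two changes. Open too, from the compounds shown here alone, is how this carbon would respond to a benzenesulfonamide on a methylene link, a longer alkyl chain on the sulfonyl, an amine or a carboxylic acid.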